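Rejoining the same atoms: compound 3 to compound 4

This account rests on a few compounds, and the source may have more. Where it says the series, first, only, none or still open, it means among the compounds named here.

Measured so far in a functional assay on HCT-116 cells (Homo sapiens) for cytotoxicity, read by MTT assay; a higher number here means a weaker inhibitor, a lower number a stronger inhibitor
compound 1 `Nc1ccccc1NC(=O)c1ccc(CNc2cccc(F)n2)cc1` gives 1000 nM
compound 2 `Nc1nc(NCc2ccc(C(=O)Nc3ccccc3N)cc2)nc(NC2CCCC2)n1` gives 700 nM
compound 3 `Nc1nc(NCc2ccc(C(=O)Nc3ccccc3N)cc2)nc(N2CCc3ccccc32)n1` gives 800 nM

These three values sit so close together that repeat measurements could not tell them apart. Compound 3 lies within the usual scatter of both compound 1 and compound 2, so it stands level with them rather than ahead or behind.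

Compound 4 `Nc1nc(NCc2ccc(C(=O)Nc3ccccc3N)cc2)nc(N2Cc3ccccc3C2)n1` has the same atoms as compound 3, joined differently. The change is a group of 9 heavy atoms (8 carbon, 1 nitrogen; one five-membered non-aromatic ring with 1 hetero atom, one six-membered aromatic ring of carbon only) in place of a group of 9 heavy atoms (8 carbon, 1 nitrogen; one five-membered non-aromatic ring with 1 hetero atom, one six-membered aromatic ring of carbon only), on an aromatic carbon and it falls on an aromatic carbon between two ring nitrogen atoms.

For the measured compounds named here, only one measured step bears on this place. It is a 1.1-fold higher number from compound 2 to compound 3 (0.06 log units; within the scatter) and it put 2,3-dihydro-1H-indol-1-yl in place of cyclopentylamino. That swap stayed within the scatter, though the exact rearrangement in compound 4 has not been measured.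

No step beyond the scatter is therefore expected in either direction, and the estimate is a 1.1-fold lower number from compound 3 to compound 4 (0.03 log units; within the scatter) (in this assay). Compound 4 is expected at 750 nM (estimated range 350 nM to 1600 nM).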

Compound 4, half-maximal inhibitory concentration: 500 nM
Compound 4: the middle estimate sits 1.5-fold (0.18 log units) above what was measured; the range from low to high includes it.
By their numbers in this assay, from the lowest: compounds 4, 2, 3 and 1 (each within the scatter of the next).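

Rejoining the atoms of 2,3-dihydro-1H-indol-1-yl on the aromatic carbon between two ring nitrogen atoms gives a 1.6-fold lower number from compound 3 to compound 4 (0.20 log units; within the scatter) in this assay, so this rearrangement of the same two rings leaves the reading within the usual scatter. Compared with cyclopentylamino at the same place, the new group gives a 1.4-fold lower number from compound 2 to compound 4 (0.15 log units; within the scatter), so compounds 2, 3 and 4 cannot be told apart in this assay despite their different groups at this position. Nothing measured here offers any explanation for how closely these readings agree.

On these data alone, it remains open whether this position would stay as flat with a quite different group, such as a morpholine, a carboxylic acid or a longer alkyl chain. As far as these compounds go, it is also open whether these readings would hold if the amino group on the same ring were replaced.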